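Acetoxy for methylpiperazine on the oxazolidinone side chain

A few compounds are considered here, and "the series" means these few. Any claim that something is new, unique, unknown or untested is made for them only; others in the source may bear on it.

The series shares one core and differs only in the group carried on a saturated chain carbon bound to a saturated ring carbon. In a physicochemical assay for lipophilicity, read by HPLC, measured as octanol-water partition (a higher number here means a more lipophilic compound, a lower number a more polar compound), compound 1 `CN1CCN(C[C@H]2CN(c3ccc(-n4cc(-c5ccccn5)cn4)c(F)c3)C(=O)O2)CC1` gives 2.2, the highest of the three numbers recorded. Compound 2 `O=C1CNC(=O)N1C[C@H]1CN(c2ccc(-n3cc(-c4ccccn4)cn3)c(F)c2)C(=O)O1` gives 1.25 in this assay, and compound 3 `O=C1CSC(=O)N1C[C@H]1CN(c2ccc(-n3cc(-c4ccccn4)cn3)c(F)c2)C(=O)O1` gives 2.18. The steps show a number 0.95 log units lower from compound 1 to compound 2 (beyond the scatter) and a number 0.02 log units lower from compound 1 to compound 3 (within the scatter), while a number 0.93 log units higher from compound 2 to compound 3 (beyond the scatter).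

Compound 4 `CC(=O)OC[C@H]1CN(c2ccc(-n3cc(-c4ccccn4)cn3)c(F)c2)C(=O)O1` carries the change (acetoxy in place of 4-methylpiperazin-1-yl on a saturated chain carbon bound to a saturated ring carbon). Going by the values given here, no measured step covers acetoxy itself; the two measured exchanges of the 4-methylpiperazin-1-yl group gave one modest fall and one step within the scatter, so the group leaving does not itself fix the direction. Since an acetoxy group, like the 2,4-dioxo-1,3-thiazolidin-3-yl group of compound 3, carries two acceptors and no donor, a step of similar size to a number 0.02 log units lower from compound 1 to compound 3 (within the scatter) is expected, that is no step beyond the scatter. Compound 4 is therefore estimated at 2.4 in this assay, within 1.9 to 2.9, an expected step of a number 0.20 log units higher from compound 1 to compound 4 (within the scatter).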

Compound 4, partition coefficient: 2.09
Estimate against measurement, compound 4: 0.31 log units above; measured number inside the range.
By their numbers in this assay, from the lowest: compound 2; then compounds 4, 3 and 1 (each within the scatter of the next).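

Going by these compounds alone, on the saturated chain carbon bound to a saturated ring carbon, acetoxy is the first entering group here without a ring, and in this assay replacing 4-methylpiperazin-1-yl with it gives no step beyond the scatter (a number 0.11 log units lower from compound 1 to compound 4 (within the scatter)). Acetoxy also stands within the scatter of the 2,4-dioxo-1,3-thiazolidin-3-yl group (a number 0.09 log units lower from compound 3 to compound 4 (within the scatter)), while the 2,5-dioxoimidazolidin-1-yl group remains apart (a number 0.84 log units higher from compound 2 to compound 4 (beyond the scatter)), so compound 2 alone separates from the other three. Nothing measured here explains this grouping.

The compounds shown leave open whether a free hydroxyl or a primary amine at this position would stay with compound 1, compound 3 and compound 4 or fall toward compound 2. They also leave open how a longer ester chain, such as butanoyloxy, or a carboxylic acid would read here.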